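The source may hold more compounds than are shown below. What is called first, only, known or untested is meant among the compounds shown, and "the series" means these compounds.

In a functional assay on DU-145 cells (Homo sapiens) for antiproliferative activity, with a stated time of 48 h (on this read-out higher numbers stand for weaker inhibition and lower numbers for stronger inhibition), compound 3 `Cc1cc(=O)c2c(OC[C@@H]3CO3)cc(OC[C@H]3CO3)cc2o1` gives 20400 nM and compound 1 `Cc1cc(=O)c2c(OC[C@H]3CO3)cc(OC[C@H]3CO3)cc2o1` gives 15600 nM, two values within the scatter of each other. Compound 2 `Cc1cc(=O)c2c(O)cc(OC[C@@H]3CO3)cc2o1` gives 7580 nM, a lower number than that of compound 3, and so stronger inhibition.

Compound 4 `Cc1cc(=O)c2c(OC[C@H]3CO3)cc(OC[C@@H]3CO3)cc2o1` has not yet been measured. Set against compound 3, it shows this difference: the two compounds have the same atoms and bonds and differ only in configuration as drawn: 2 of 2 stereo elements differ (all stereocentres are inverted: mirror images); a stereocentre at a saturated ring carbon is drawn S in compound 3 and R in compound 4; a stereocentre at a saturated ring carbon is drawn R in compound 3 and S in compound 4. Within the data shown here, only one measured step bears on this change: a 1.3-fold higher number from compound 1 to compound 3 (0.12 log units; within the scatter). That step inverts a single stereocentre, and its size stays within the scatter. Compound 4 inverts both stereocentres, so the evidence covers only part of the change, and the range must stay wide. With that one step as the guide, no shift beyond the scatter is expected in this assay. The estimated change is a 1.1-fold lower number from compound 3 to compound 4 (0.05 log units; within the scatter), which would be no real change in either direction. For compound 4 the estimated value is 18000 nM, with an expected range from 9000 nM to 33000 nM.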

Compound 4, half-maximal inhibitory concentration: 628000 nM
For compound 4 the middle estimate is 35-fold (1.54 log units) below the measured one, outside the stated range (above it).
By their numbers in this assay, from the lowest: compound 2; then compounds 1 and 3 (each within the scatter of the next); then compound 4.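

The result shows that configuration in this series is not silent in this assay: the single inversion that looked harmless earlier says nothing about the other stereocentre, since a 40-fold higher number from compound 1 to compound 4 (1.60 log units; beyond the scatter), and the mirror-image pair is far apart too, with a 31-fold higher number from compound 3 to compound 4 (1.49 log units; beyond the scatter). The large gaps can be traced to configuration alone, as no atom or bond changes: the fact that compounds 1 and 4 differ only in the configuration as drawn Adding (oxiran-2-yl)methyl in place of hydrogen on an oxygen on an aromatic ring also proves costly in this configuration, with an 83-fold higher number from compound 2 to compound 4 (1.92 log units; beyond the scatter), so compound 4 is the weakest of the four.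

The compounds shown leave open how the remaining stereoisomer, with both centres inverted relative to compound 1, would behave. They also leave open whether an amine or a longer chain on that oxygen would keep or lose this dependence on configuration.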